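The source may report more compounds than this note shows. Statements on the series, on what has been measured and on what is new or still open speak of the compounds shown alone.

Compound 1, `O=C1Nc2ccc(Br)cc2/C1=N/NC(=S)N/N=C/c1c(Cl)cccc1Cl`, in a functional assay on HeLa cells (Homo sapiens) for inhibition, read by MTT assay (on this read-out lower numbers stand for stronger inhibition and higher numbers for weaker inhibition), gives 3530 nM.
Compound 2, `Cc1ccc(O)c(/C=N/NC(=S)N/N=C2\C(=O)Nc3ccc(Br)cc32)c1`, in this assay gives > 50000 nM, which is a limit of the assay and not a number.

Compound 2 thus stands at the limit of this assay (the limit of > 50000 nM in this assay, at which 1 of the 2 values shown sits), with no measured number of its own. Compound 3, `COc1ccc(/C=N/NC(=S)N/N=C2\C(=O)Nc3ccc(Br)cc32)cc1O`, differs from it by 3-hydroxy-4-methoxyphenyl in place of 2-hydroxy-5-methylphenyl on a carbon with a double bond to nitrogen. Among the compounds with values here, the one measured step, an at least 14-fold higher number from compound 1 to compound 2 (1.15 log units; beyond the scatter), also changed the aryl group on that carbon and weakened inhibition greatly, so the position is sensitive, but it does not fix a direction for compound 3. He expects a step of an at least 1.2-fold lower number from compound 2 to compound 3 (0.09 log units; that floor lies within the scatter). Compound 3 is therefore estimated at 40000 nM, between 8000 nM and 100000 nM.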

Compound 3, half-maximal inhibitory concentration: 2220 nM
Beside the measured number, compound 3's estimate is 18-fold (1.26 log units) above it; measured number outside the range, below it.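

The aryl group on the carbon with a double bond to nitrogen is not restricted to 2,6-dichlorophenyl: replacing 2-hydroxy-5-methylphenyl with 3-hydroxy-4-methoxyphenyl gives an at least 22-fold lower number from compound 2 to compound 3 (1.35 log units; beyond the scatter). Compound 2 gives a limit and not a number: the limit of > 50000 nM in this assay, at which 1 of the 3 values shown sits. Against the dichlorinated group, the new group gives a 1.6-fold lower number from compound 1 to compound 3 (0.20 log units; within the scatter), so the two groups cannot be told apart here.

Going by these compounds, it remains open whether the hydroxy group, the methoxy group or their placement accounts for the recovery. On these data alone, how an amine or a carboxylic acid on this aryl ring would read also remains open.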